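Swapping an aromatic ring for a saturated one at the same spot

The compounds below may be only part of what the source reports. "The series", "measured", "known", "first", "only" and "open" are said of these compounds alone.

Measured compounds:
- compound 1 `O=[N+]([O-])c1ccc(NCc2ccccc2O)cc1`: "not active" (no number reported)
- compound 2 `Cc1cccc(-c2ccc(NCc3ccccc3O)cc2)c1`: 9190 nM

For the measured compounds named here, in a functional assay on Jurkat cells (Homo sapiens) for activation, with a stated time of 24 h (on this read-out higher numbers stand for an effect only at larger amounts of compound and lower numbers for an effect already at smaller amounts), compound 2 gives 9190 nM, the only number in this set; compound 1 shows no number at all. Compound 3 `Oc1ccccc1CNc1ccc(C2CCCCC2)cc1` has not been measured. It differs from compound 2 by cyclohexyl in place of 3-methylphenyl on an aromatic carbon. Going by the values given here, no measured pair shows what this kind of swap does here, so the expected step from compound 2 to compound 3 is a 1.3-fold higher number from compound 2 to compound 3 (0.12 log units; within the scatter), which is not beyond the usual scatter. Compound 3 is therefore expected to give about 12000 nM, within 3000 nM to 50000 nM.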

Compound 3, half-maximal effective concentration: 8800 nM
Beside the measured number, compound 3's estimate is 1.4-fold (0.13 log units) above it, within the range that was stated.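

In this assay the swap gives a 1.0-fold lower number from compound 2 to compound 3 (0.02 log units; within the scatter), so at this position, on an aromatic carbon, the saturated cyclohexyl ring and the aromatic 3-methylphenyl ring cannot be told apart. For these two groups, then, the ring at this spot need not be aromatic for the number to hold. No measurement at hand explains this result.

Still open, going by these compounds, is whether a group that is not a carbon ring, such as an amine, a carboxylic acid or a longer alkyl chain, would move the number at this position.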